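The compounds below may be only part of what the source reports. "The series", "measured", "known", "first", "only" and "open" are said of these compounds alone.

Measured compounds in an ADME assay on BHK cells (Mesocricetus auratus) for cytotoxicity, read by MTT assay, with a stated time of 96 h; on this read-out higher numbers stand for lower toxicity in this test and lower numbers for higher toxicity in this test:
- compound 1 `Cn1c(-c2ccc(NC(=O)CN3CCCC3)cc2)nc2cc(C(F)(F)F)ccc21` gives 27000 nM
- compound 2 `O=C(O)CCC(=O)Nc1ccc(-c2nc3cc(C(F)(F)F)ccc3[nH]2)cc1` gives > 100000 nM, which is a limit of the assay and not a number
- compound 3 `CC(=O)Nc1ccc(-c2nc3ccccc3[nH]2)cc1` gives > 100000 nM, which is likewise a limit of the assay and not a number

Among the three measured compounds, compound 1 is the only one with a numerical value in this assay. Going by the values given here, the other two sit at the limit of > 100000 nM in this assay, at which 2 of the 3 values shown sit, so compound 1 is the one compound here for which a half-maximal cytotoxic concentration was actually reached within the tested range.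

Compound 4 `CCC(=O)Nc1ccc(-c2nc3cc(C(F)(F)F)ccc3n2C)cc1` has not yet been measured. It differs from compound 1 in one place: methyl in place of pyrrolidin-1-yl on a saturated chain carbon bound to a carbonyl carbon. The shared core of compound 1 and compound 4 is otherwise unchanged.

Among the compounds with values here, no step between two measured compounds is available to calibrate this change, so any expectation rests on what the three values show. With two of three measured compounds at the limit of > 100000 nM in this assay, at which 2 of the 3 values shown sit, the step from compound 1 to compound 4 is expected to move toward lower toxicity, as a 2.6-fold higher number from compound 1 to compound 4 (0.41 log units; beyond the scatter), and it is expected to be larger than the scatter. Compound 4 is therefore estimated at 70000 nM, with a range from 25000 nM to 200000 nM, and there is a fair chance the assay reports only a limit.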

Compound 4, half-maximal cytotoxic concentration: > 100000 nM
Compound 4 was reported as a limit; the forecaster's own chance of this, stated with the estimate: 40%; at least 1.4-fold (0.15 log units) between middle value and limit.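

In this assay, going by these compounds alone, the change on a saturated chain carbon bound to a carbonyl carbon gives the first step that can be read between two compounds differing in one place, and replacing pyrrolidin-1-yl with methyl gives an at least 3.7-fold higher number from compound 1 to compound 4 (0.56 log units; beyond the scatter). The shared core of compound 1 is kept, and compound 4 gives > 100000 nM, which is a limit of the assay and not a number, so this core with its methyl group does not on its own bring a half-maximal cytotoxic concentration into the tested range. The only number in the set therefore stays with the compound that carries pyrrolidin-1-yl at this place: the limit of > 100000 nM in this assay, at which 3 of the 4 values shown sit.

How large the step really is stays open, since only its lower bound can be read, and the compounds shown do not separate the role of the ring in pyrrolidin-1-yl from that of its nitrogen. A dimethylamino group, a piperidin-1-yl ring or a cyclopentyl ring at the same place would be needed to tell whether the amine, the ring size or the ring itself goes with the number seen for compound 1.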